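The source may hold more compounds than are shown below. What is called first, only, known or untested is meant among the compounds shown, and "the series" means these compounds.

Measured so far in an assay on membranes from HeLa cells for displacement of a labelled ligand from adenosine receptor A3 (Homo sapiens), read by scintillation counting, with a stated time of 180 min, tested at 1 uM; a lower number here means less inhibition, a higher number more inhibition at the concentration tested (going by the name of the read-out):
compound 1, `CC1=C(C(=O)OC(C)(C)C)C(c2cccs2)NC(=S)N1`, 22%;
compound 2, `CC1=C(C(=O)OCc2ccccc2)C(c2cccs2)NC(=S)N1`, 24%;
compound 3, `CC1=C(C(=O)OC(C)(C)C)C(c2ccoc2)NC(=O)N1C`, 12%.

Compound 1 and compound 2 share one core and differ in a single place: benzyl in place of tert-butyl on an oxygen next to a carbonyl group. This change moved the read-out by a number 2 percentage points higher from compound 1 to compound 2 (within the scatter). Compound 3 has a different core; how it differs from compound 1 is not broken down here. Compound 4, `CC1=C(C(=O)OCc2ccccc2)C(c2ccoc2)NC(=O)N1C`, has not yet been measured in this assay; it is made from compound 3 by the same change: benzyl in place of tert-butyl on an oxygen next to a carbonyl group. Because the earlier step was a number 2 percentage points higher from compound 1 to compound 2 (within the scatter), a step of about the same small size is expected from compound 3 to compound 4, a number 2 percentage points higher from compound 3 to compound 4 (within the scatter). Compound 4 is therefore expected to give about 14%, within 4% to 26%, in this assay.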

Compound 4, a percentage reported as inhibition, at one concentration (the size of the read-out at that concentration, not a potency): 25%
Compound 4: the middle estimate sits 11 percentage points below what was measured; low and high end bracket the measured number.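

On the core of compound 3, benzyl in place of tert-butyl on an oxygen next to a carbonyl group gave a number 13 percentage points higher from compound 3 to compound 4 (beyond the scatter) in this assay. Set beside the earlier step, this one cannot be told apart from it, so the two cores give no sign that the change behaves differently from one to the other: the same change on two cores in this assay, a number 2 percentage points higher (within the scatter) from compound 1 to compound 2 and a number 13 percentage points higher (beyond the scatter) from compound 3 to compound 4, 11 percentage points apart, within the scatter of two such steps

Within the data shown here, this is a comparison of only two cores, so it does not show that the step would keep the same size on other cores.

The compounds shown leave open what other groups on this oxygen would do, such as ethyl or a longer chain. They also leave open whether the step would hold on a core carrying an amine.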